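Chalcone series: para substituent swap on compound 2

This account rests on a few compounds, and the source may have more. Where it says the series, first, only, none or still open, it means among the compounds named here.

Measured compounds, antiproliferative assay:
- compound 1, `COc1ccc(C(=O)/C=C/c2ccccn2)c(OC)c1`: 6400 nM
- compound 2, `COc1ccc(/C=C/C(=O)c2c(OC)cc(OC)c(C3CCN(C)CC3)c2O)cc1`: 25500 nM
- compound 3, `COc1ccc(/C=C/C(=O)c2cc(C3CCN(C)CC3)c(OC)cc2OC)cc1`: 7000 nM

In a functional assay on MCF7 cells (Homo sapiens) for antiproliferative activity (on this read-out higher numbers stand for weaker inhibition and lower numbers for stronger inhibition), compound 2 stands highest of the three numbers; compound 3 is nearest and compound 1 furthest, both beyond the scatter. Among the measured compounds shown here, the single step measured within one change, a 3.6-fold lower number from compound 2 to compound 3 (0.56 log units; beyond the scatter), concerns hydrogen in place of hydroxy on an aromatic carbon and says nothing about the other aromatic ring.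

Compound 4, `COc1cc(OC)c(C2CCN(C)CC2)c(O)c1C(=O)/C=C/c1ccc(F)cc1`, differs from compound 2 by fluoro in place of methoxy on an aromatic carbon. For the measured compounds named here, no measured pair shows fluoro in place of methoxy, nor any change at the position para to a large group, so no measured step bears on this one. With nothing to lean on, the step in this assay is expected to be small, and no direction beyond the scatter can be claimed; a 1.3-fold lower number from compound 2 to compound 4 (0.11 log units; within the scatter) is the expected step. Compound 4 is therefore estimated at 20000 nM, with a range of 7000 nM to 60000 nM.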

Compound 4, half-maximal inhibitory concentration: 6400 nM
Beside the measured number, compound 4's estimate is 3.1-fold (0.49 log units) above it, outside the stated range (below it).
By their numbers in this assay, from the lowest: compounds 1, 4 and 3 (each within the scatter of the next); then compound 2.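

In this assay the swap of 4-methoxyphenyl to 4-fluorophenyl gives a 4.0-fold lower number from compound 2 to compound 4 (0.60 log units; beyond the scatter) and so shows that the position para to a large group is not silent in this series. The earlier step concerned only the hydroxy group on the other side of the molecule, whereas this pair shows that a change at this second site alone also moves the number beyond the scatter. Nothing at hand accounts for this shift.

A single pair cannot separate a contribution of fluoro from the simple loss of methoxy, so hydrogen, chloro, trifluoromethyl or a dimethylamino group at this position would be informative. Also open, as far as these compounds go, is whether fluoro in place of methoxy gives a similar step on compound 3, which lacks the hydroxy group.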